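A few compounds are considered here, and "the series" means these few. Any claim that something is new, unique, unknown or untested is made for them only; others in the source may bear on it.

In an ADME assay on HeLa Rh cells (Homo sapiens) for cytotoxicity, read by microscopy (a lower number here means that less compound is tolerated, a higher number that more compound is tolerated), compound 2 `COc1cc(CC(O)c2ccc(-c3ccc(C(F)(F)F)cc3)cc2)c([N+](=O)[O-])cc1OC` gives 4100 nM. Going by the values given here, its only companion is compound 1 `COc1cc(CC(O)c2ccc(-c3ccc(C#N)cc3)cc2)c([N+](=O)[O-])cc1OC`, which in this assay gives 4700 nM; the two stand within the scatter of each other, a 1.1-fold lower number from compound 1 to compound 2 (0.06 log units; within the scatter). Compound 3 `COc1ccc(-c2ccc(C(O)Cc3cc(OC)c(OC)cc3[N+](=O)[O-])cc2)cc1` differs from compound 2 by a single change: methoxy in place of trifluoromethyl on an aromatic carbon. Among the compounds with values here, the one measured step at this position, a 1.1-fold lower number from compound 1 to compound 2 (0.06 log units; within the scatter), left the number within the scatter. A further exchange at the same position is therefore expected to move it no further, a 1.0-fold higher number from compound 2 to compound 3 (0.02 log units; within the scatter). Compound 3 is estimated at 4300 nM, with a range from 1500 nM to 12000 nM.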

Compound 3, half-maximal cytotoxic concentration: > 244000 nM
Compound 3 ended at the assay's limit (the forecaster's own chance of this, stated with the estimate: 5%); middle value at least 56-fold (1.75 log units) from the limit.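

The position is not indifferent to what sits on it, although cyano and trifluoromethyl had stayed within the scatter of each other. Methoxy in place of trifluoromethyl gives an at least 59-fold higher number from compound 2 to compound 3 (1.77 log units; beyond the scatter), and methoxy in place of cyano gives an at least 51-fold higher number from compound 1 to compound 3 (1.71 log units; beyond the scatter). The value of compound 3 in this assay is a limit and not a number: the limit of > 244000 nM in this assay, at which 1 of the 3 values shown sits.

The compounds shown leave open whether this large step belongs to methoxy alone or would also appear with a hydroxyl, an ethoxy or an amine on the same aromatic carbon.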